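Methoxy for fluoro on the anilino ring of compound 3

A few compounds are considered here, and "the series" means these few. Any claim that something is new, unique, unknown or untested is made for them only; others in the source may bear on it.

Among the measured compounds shown here, the three compounds measured so far share one core and differ only in the aryl group on the nitrogen. Compound 1 `COc1cc2ncnc(Nc3ccc(Cl)c(C(F)(F)F)c3)c2cc1OCCCCC(=O)Nc1ccc(S(N)(=O)=O)cc1` gives 3220 nM in a functional assay on NCI-H1975 cells (Homo sapiens) for antiproliferative activity, read by MTT assay, with a stated time of 72 h; on this read-out lower numbers stand for stronger inhibition and higher numbers for weaker inhibition. Compound 2 `COc1cc2ncnc(Nc3cccc(Cl)c3)c2cc1OCCCCC(=O)Nc1ccc(S(N)(=O)=O)cc1` gives 33200 nM in this assay. Compound 3 `COc1cc2ncnc(Nc3ccc(F)cc3)c2cc1OCCCCC(=O)Nc1ccc(S(N)(=O)=O)cc1` reaches only the limit > 40000 nM in this assay, so no number is known for it. Compound 3 therefore stands at the weak end of what has been seen, marked by the limit of > 40000 nM in this assay, at which 1 of the 3 values shown sits. The steps of a 10-fold higher number from compound 1 to compound 2 (1.01 log units; beyond the scatter) and an at least 12-fold higher number from compound 1 to compound 3 (1.09 log units; beyond the scatter) were large, while an at least 1.2-fold higher number from compound 2 to compound 3 (0.08 log units; that floor lies within the scatter) stays within the scatter. Compound 4 `COc1ccc(Nc2ncnc3cc(OC)c(OCCCCC(=O)Nc4ccc(S(N)(=O)=O)cc4)cc23)cc1` differs from compound 3 by methoxy in place of fluoro on an aromatic carbon. For the measured compounds named here, none of the measured steps changes this group in this way, so they bear on it only indirectly: both small aryl groups sat far from compound 1. He therefore expects for compound 4 a step of a number no higher from compound 3 to compound 4 (the limit leaves the size open) of no clear size beyond the scatter. His estimate for compound 4 is 40000 nM, within 12000 nM to 120000 nM, with a fair chance that only a limit is again reported.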

Compound 4, half-maximal inhibitory concentration: 30200 nM
Beside the measured number, compound 4's estimate is 1.3-fold (0.12 log units) above it; the range from low to high includes it.
By their numbers in this assay, from the lowest: compound 1; then compounds 4 and 2 (each within the scatter of the next). At a limit, above all of these: compound 3.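

The change of fluoro to methoxy, para to a large group, gives an at least 1.3-fold lower number from compound 3 to compound 4 (0.12 log units; that floor lies within the scatter), so in this assay it brings no gain that can be told from the scatter, though compound 4 does give a number. The step of a 1.1-fold lower number from compound 2 to compound 4 (0.04 log units; within the scatter) puts the 4-methoxyphenyl and 3-chlorophenyl groups level, while a 9.4-fold higher number from compound 1 to compound 4 (0.97 log units; beyond the scatter) leaves the 4-chloro-3-(trifluoromethyl)phenyl group of compound 1 clear of the other aryl groups that have numbers. Compound 3 remains a limit and not a number, so the true size of its step to compound 4 cannot be read: the limit of > 40000 nM in this assay, at which 1 of the 4 values shown sits.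

Going by these compounds, whether the chloro or the trifluoromethyl part of the group in compound 1 carries its lower number stays open. So does the effect of an amine or a nitrile in place of methoxy on this aromatic carbon.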